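Benzyl for Phenyl Carried onto a Second Core

The compounds below may be only part of what the source reports. "The series", "measured", "known", "first", "only" and "open" are said of these compounds alone.

Compound 1 `Nc1ccccc1NC(=O)c1ccc(Cn2cnc3c(Nc4ccccc4)nc(Cl)nc32)cc1` gives 77.8% in a functional assay on NCI-H460 cells (Homo sapiens) for antiproliferative activity, read by CCK-8 assay, with a stated time of 72 h, tested at 8 uM; a lower number here means a weaker effect, a higher number a stronger effect of the compound at the concentration tested. Compound 2 `Nc1ccccc1NC(=O)c1ccc(Cn2cnc3c(NCc4ccccc4)nc(Cl)nc32)cc1` differs from compound 1 by benzyl in place of phenyl on a nitrogen on an aromatic ring; in this assay compound 2 gives 61.2%, a step of a number 16.6 percentage points lower from compound 1 to compound 2 (beyond the scatter). Compound 3 `Nc1ccccc1NC(=O)/C=C/c1ccc(Cn2cnc3c(Nc4ccccc4)nc(Cl)nc32)cc1` carries a different core, differing from compound 1 by 2-((2-aminophenyl)carbamoyl)ethenyl in place of (2-aminophenyl)carbamoyl on an aromatic carbon; in this assay compound 3 gives 28.7%, a step of a number 49.1 percentage points lower from compound 1 to compound 3 (beyond the scatter). Compound 4 `Nc1ccccc1NC(=O)/C=C/c1ccc(Cn2cnc3c(NCc4ccccc4)nc(Cl)nc32)cc1` is not yet measured and differs from compound 3 by benzyl in place of phenyl on a nitrogen on an aromatic ring, the same change as that made from compound 1 to compound 2, at the same place. If that change acts alike on the core of compound 3, a step of a number 14.7 percentage points lower from compound 3 to compound 4 (beyond the scatter) is expected, set beside the earlier one because of a number 16.6 percentage points lower from compound 1 to compound 2 (beyond the scatter). The value of compound 3, 28.7%, leaves little room beneath it, and the expected step is kept somewhat smaller for that reason. Compound 4 is thus expected to give about 14% in this assay, between 2% and 30%.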

Compound 4, a percentage reported as inhibition, at one concentration (the size of the read-out at that concentration, not a potency): 49.1%
Beside the measured number, compound 4's estimate is 35.1 percentage points below it; measured number outside the range, above it.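

Benzyl in place of phenyl on the nitrogen gave a number 20.4 percentage points higher from compound 3 to compound 4 (beyond the scatter) in this assay and so did not carry from one core to the other: the same change on two cores in this assay, a number 16.6 percentage points lower (beyond the scatter) from compound 1 to compound 2 and a number 20.4 percentage points higher (beyond the scatter) from compound 3 to compound 4, 37 percentage points apart, beyond the scatter of two such steps. Read the other way, 2-((2-aminophenyl)carbamoyl)ethenyl in place of (2-aminophenyl)carbamoyl gave a number 12.1 percentage points lower from compound 2 to compound 4 (beyond the scatter) and cost less with benzyl present than with phenyl: the same change on two cores in this assay, a number 49.1 percentage points lower (beyond the scatter) from compound 1 to compound 3 and a number 12.1 percentage points lower (beyond the scatter) from compound 2 to compound 4, 37 percentage points apart, beyond the scatter of two such steps. These four compounds show that the two changes do not add up independently in this assay, but they do not show why, nor whether the reversal extends beyond this pair of cores.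

From the compounds shown here alone, whether a longer chain in place of benzyl, or a cyclohexyl group in place of phenyl, follows compound 4 or compound 2 stays open. So does whether the same reversal appears in other cell lines.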